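This account rests on a few compounds, and the source may have more. Where it says the series, first, only, none or still open, it means among the compounds named here.

Measured so far in a functional assay on CHO-K1 cells for antagonist activity at transient receptor potential cation channel subfamily V member 1 (Homo sapiens), read by FLIPR; a higher number here means a weaker inhibitor, a lower number a stronger inhibitor:

compound 1, `CC(C(=O)NCc1ccc(C(F)(F)F)nc1NCc1ccccc1)c1ccc(NS(C)(=O)=O)c(F)c1`: 15.8 nM
compound 2, `CC1CCCN1c1nc(C(F)(F)F)ccc1CNC(=O)[C@@H](C)c1ccc(NS(C)(=O)=O)c(F)c1`: 0.3 nM
compound 3, `CC(C(=O)NCc1ccc(C(F)(F)F)nc1N1CCC(C(=O)c2ccc(F)cc2)CC1)c1ccc(NS(C)(=O)=O)c(F)c1`: 3.9 nM

Compound 1 has the highest number of the three. The nearest value is that of compound 3 at 3.9 nM, a gap that lies beyond the scatter; the furthest is that of compound 2 at 0.3 nM, well beyond the scatter. Both lower-numbered compounds carry a ring-closed amine in place of the benzylamino of compound 1, and both do better in this assay than compound 1 does.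

Compound 4, `CC(C(=O)NCc1ccc(C(F)(F)F)nc1N1CCCCCCC1)c1ccc(NS(C)(=O)=O)c(F)c1`, is not yet measured. Relative to compound 1 the change is a group of 8 heavy atoms (7 carbon, 1 nitrogen; one eight-membered non-aromatic ring with 1 hetero atom) in place of a group of 8 heavy atoms (7 carbon, 1 nitrogen; one six-membered aromatic ring of carbon only), on an aromatic carbon. Compound 4 thus joins compounds 2 and 3 in carrying a non-aromatic ring with one hetero atom on the core in place of benzylamino, although its ring is larger than that of either and carries nothing further. On the values of compound 2 and compound 3, a step downward from compound 1 beyond the scatter is expected for compound 4, though whether it reaches the level of compound 2 cannot be told from three compounds. The step expected is a 7.9-fold lower number from compound 1 to compound 4 (0.90 log units; beyond the scatter). Compound 4 is estimated at 2 nM, with a range from 0.5 nM to 8 nM.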

Compound 4, inhibition constant: 0.7 nM
The estimate for compound 4 lay 2.9-fold (0.46 log units) above the measured number, and the stated range covers the measured number.
By their numbers in this assay, from the lowest: compound 2; then compound 4; then compound 3; then compound 1.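

Working from this assay, the benzylamino group on the aromatic carbon next to the ring nitrogen can be exchanged for the eight-membered non-aromatic ring with a large gain, a 23-fold lower number from compound 1 to compound 4 (1.35 log units; beyond the scatter), and this is the one step in the series that can be read between measured compounds differing in one place. The heavy-atom count stays the same across this change, so the step arises without any change in that count; what does change is an aromatic ring giving way to a non-aromatic ring, and the hydrogen-bond donor being lost, while compound 4 reaches 0.7 nM with nothing further on its ring. No measurement available here bears on why the number falls, so the part played by each of these differences remains unassigned.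

The compounds shown leave open whether the donor or the ring type carries the step, a question that a benzylamino group with a methyl on its nitrogen would address. They also leave open whether a ring is needed at all at this position, as against an open-chain amine such as dipropylamino.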